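The source may report more compounds than this note shows. Statements on the series, on what has been measured and on what is new or still open speak of the compounds shown alone.

In a functional assay on HT-29 cells (Homo sapiens) for inhibition, read by MTT assay, with a stated time of 72 h (a lower number here means a stronger inhibitor, a higher number a weaker inhibitor), three compounds share one core and differ only in the group on the amine nitrogen. Compound 1 `CCC(C)NC(=C\C(=O)/C=C/c1ccc(O)c(OC)c1)/C=C/c1ccc(O)c(OC)c1` gives > 25000 nM, which is a limit of the assay and not a number. Compound 2 `C=CCNC(=C\C(=O)/C=C/c1ccc(O)c(OC)c1)/C=C/c1ccc(O)c(OC)c1` gives > 25000 nM, again a limit. Compound 3 `COc1cc(/C=C/C(=O)/C=C(/C=C/c2ccc(O)c(OC)c2)NC2CCCCC2)ccc1O` gives > 25000 nM, also a limit, so it has no number of its own. The series therefore stands at the limit of > 25000 nM in this assay, at which 3 of the 3 values shown sit.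

Compound 4 `COc1cc(/C=C/C(=O)/C=C(/C=C/c2ccc(O)c(OC)c2)NCC(C)C)ccc1O` changes the same place: isobutyl in place of cyclohexyl on an amine nitrogen. Within the data shown here, the steps that bear on this one also swap the group on that nitrogen, and none has a readable size: a step that the two limits leave unreadable from compound 1 to compound 2, a step that the two limits leave unreadable from compound 1 to compound 3 and a step that the two limits leave unreadable from compound 2 to compound 3. Because of the limit of > 25000 nM in this assay, at which 3 of the 3 values shown sit, no direction can be carried over from compound 1, compound 2 or compound 3, and compound 4 is expected to stay at the limit of the assay as well. The expected change is a step that the limit leaves unreadable from compound 3 to compound 4, with nothing expected beyond the scatter. For compound 4 the estimated value is 30000 nM, with an expected range of 15000 nM to 60000 nM.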

Compound 4, half-maximal inhibitory concentration: 24500 nM
The estimate for compound 4 lay 1.2-fold (0.09 log units) above the measured number; low and high end bracket the measured number.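

In this assay compound 4, with isobutyl on the amine nitrogen, is the only one of the four to give a number rather than a limit: 24500 nM. The steps read an at least 1.0-fold lower number from compound 3 to compound 4 (0.00 log units; that floor lies within the scatter), an at least 1.0-fold lower number from compound 2 to compound 4 (0.00 log units; that floor lies within the scatter) and an at least 1.0-fold lower number from compound 1 to compound 4 (0.00 log units; that floor lies within the scatter), so these data do not separate compound 4 from the other three. Even this number leaves the series at the edge of what the assay can read: the limit of > 25000 nM in this assay, at which 3 of the 4 values shown sit.

Going by these compounds, it stays open whether any group on this nitrogen would bring the value clearly away from that limit, for example a benzyl group, a longer chain or a chain ending in a carboxylic acid. On these data alone, how far compounds 1, 2 and 3 actually lie beyond their limits also stays open, and so does any ranking among the four.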